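Chloro on the Phenyl of a Benzofuran Pyrazoline

A few compounds are considered here, and "the series" means these few. Any claim that something is new, unique, unknown or untested is made for them only; others in the source may bear on it.

Compound 1, with the structure `COc1ccc(C2CC(c3ccccc3)=NN2C(=O)c2cc3ccccc3o2)cc1OC`, gives 6.89 ug/mL in a functional assay on A2780 cells (Homo sapiens) for antiproliferative activity, read by MTT assay, with a stated time of 72 h; on this read-out lower numbers stand for stronger inhibition and higher numbers for weaker inhibition. Compound 2, with the structure `COc1ccc(C2CC(c3ccc(Cl)cc3)=NN2C(=O)c2cc3ccccc3o2)cc1OC`, carries the change chloro in place of hydrogen on an aromatic carbon relative to compound 1, and in this assay compound 2 gives 6.29 ug/mL, a step of a 1.1-fold lower number from compound 1 to compound 2 (0.04 log units; within the scatter). Compound 3, with the structure `O=C(c1cc2ccccc2o1)N1N=C(c2ccc(F)cc2)CC1c1ccccc1`, has a different core; the difference between the two cores is not broken down here. In this assay compound 3 gives 11.8 ug/mL, and its number and those of compound 1 and compound 2 all lie within the usual scatter of one another, so no order can be read among them. Compound 4, with the structure `O=C(c1cc2ccccc2o1)N1N=C(c2ccc(F)cc2)CC1c1ccc(Cl)cc1`, carries the change chloro in place of hydrogen on an aromatic carbon relative to compound 3, the same change that separates compound 1 and compound 2, at a place described in the same words. Going by the values given here, the step from compound 3 to compound 4 is expected to be a 1.1-fold lower number from compound 3 to compound 4 (0.05 log units; within the scatter), resting on the single earlier example of this change, the step of a 1.1-fold lower number from compound 1 to compound 2 (0.04 log units; within the scatter), which stayed within the scatter. Compound 4 is therefore estimated at 10.5 ug/mL, with a likely range from 6 ug/mL to 18 ug/mL.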

Compound 4, half-maximal inhibitory concentration: > 50 ug/mL
Compound 4: no number, only a limit; the forecaster's own chance of this, stated with the estimate: 5%; middle value at least 4.7-fold (0.67 log units) from the limit.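

Chloro in place of hydrogen on an aromatic carbon gives, in this assay, a step of an at least 4.2-fold higher number from compound 3 to compound 4 (0.62 log units; beyond the scatter), so this change does not carry over unchanged between these two cores: the same change on two cores in this assay, a 1.1-fold lower number (0.04 log units; within the scatter) from compound 1 to compound 2 and an at least 4.2-fold higher number (0.62 log units; beyond the scatter) from compound 3 to compound 4, at least 4.6-fold (0.66 log units) apart, beyond the scatter of two such steps

Compound 4 gives > 50 ug/mL, which is a limit of the assay and not a number, so the full size of its step remains unknown: the limit of > 50 ug/mL in this assay, at which 1 of the 4 values shown sits.

Going by these compounds alone, with only one pair on each core, this shows that the earlier step was a poor guide for the core of compound 3, but it does not show which difference between the cores separates the two results, and it gives no rule for any other core.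

The compounds shown leave open whether another group in the same place, such as bromo, an amine or a carboxylic acid, would follow chloro on either core. They also leave open which of the two steps a third core would resemble.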